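Phenyl for thiophen-2-yl on a nitrile pyridone core

The compounds below may be only part of what the source reports. "The series", "measured", "known", "first", "only" and "open" are said of these compounds alone.

Of the compounds shown here, three have been tested in a functional assay on SN12C cells (Homo sapiens) for inhibition, read by sulforhodamine B assay, with a stated time of 48 h; on this read-out higher numbers stand for weaker inhibition of growth and lower numbers for stronger inhibition of growth. Compound 1 `COc1ccc(-c2cc(-c3cccn3C)c(C#N)c(=O)[nH]2)cc1OC` gives a result that is a limit of the assay rather than a number, > 100000 nM. Compound 2 `Cn1cccc1-c1cc(-c2cccs2)nc(N)c1C#N` likewise gives only a limit, > 100000 nM. Compound 3 `Cn1cccc1-c1cc(-c2cccs2)[nH]c(=O)c1C#N` also stops at a limit, > 100000 nM. On the numbers shown, therefore, compound 3 cannot be placed above or below the others: every value recorded sits at the limit of > 100000 nM in this assay, at which 3 of the 3 values shown sit, and no step between measured compounds can be drawn from it.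

The step now taken leads from compound 3 to compound 4 `Cn1cccc1-c1cc(-c2ccccc2)[nH]c(=O)c1C#N`, which has not yet been measured in this assay. The change is phenyl in place of thiophen-2-yl on an aromatic carbon. Among the measured compounds shown here, since no measured step exists among the three known compounds, there is nothing in the data to say that this change moves the read-out in either direction; the expectation is no step beyond the usual scatter, with the growth-inhibitory concentration of compound 4 remaining at or near the same limit.

Compound 4 is therefore expected to give about 100000 nM in this assay, within a range of 50000 nM to 300000 nM. The step that this estimate implies, a number no higher from compound 3 to compound 4 (the limit leaves the size open), is expected to be no larger than the scatter.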

Compound 4, concentration for 50% growth inhibition: > 100000 nM
Compound 4: no number, only a limit; the forecaster's own chance of this, stated with the estimate: 85%; the middle value lies on the limit itself.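

Among the compounds shown here, compound 4, like compound 3, gives only a limit in this assay, so no step between compound 3 and compound 4 can be read: the limit of > 100000 nM in this assay, at which 4 of the 4 values shown sit.

The compounds shown leave open whether phenyl in place of thiophen-2-yl alters growth inhibition at all, and which change to the shared core would yield a value that is a number.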